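The source may hold more compounds than are shown below. What is called first, only, known or untested is meant among the compounds shown, and "the series" means these compounds.

Compound 3 `COC(=O)c1ccc(ON2C(=O)[C@@H](NC(=O)OCCCCC3CCCCC3)[C@@H]2C)cc1` gives 17 nM in an assay on HEK293 cells for inhibition of N-acylethanolamine-hydrolyzing acid amidase (Homo sapiens), read by fluorescence, with stated times of 10 min and 50 min (a lower number here means a stronger inhibitor, a higher number a weaker inhibitor), the lowest of the three numbers measured. Compound 1 `CCCCCCCON1C(=O)[C@@H](NC(=O)OCCCCC2CCCCC2)[C@@H]1C` gives 2230 nM in this assay, and compound 2 `C[C@H]1[C@H](NC(=O)OCCCCC2CCCCC2)C(=O)N1OCCCCC1CCCCC1` gives 3470 nM. The step of a 1.6-fold higher number from compound 1 to compound 2 (0.19 log units; within the scatter) stays within the scatter, whereas a 130-fold lower number from compound 1 to compound 3 (2.12 log units; beyond the scatter) and a 200-fold lower number from compound 2 to compound 3 (2.31 log units; beyond the scatter) are large.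

Compound 4 `C[C@H]1[C@H](NC(=O)OCCCCC2CCCCC2)C(=O)N1Oc1ccc(S(C)(=O)=O)cc1` differs from compound 3 by methylsulfonyl in place of methoxycarbonyl on an aromatic carbon. Among the compounds with values here, none of the measured steps bears directly on this change: each of them alters the group on the ring-nitrogen oxygen as a whole, while this exchange keeps the aromatic ring and replaces only the substituent on it. The group that leaves and the group that enters are each counted with the same number of hydrogen-bond acceptors and no donors, so the expectation is that the step of a 1.5-fold higher number from compound 3 to compound 4 (0.17 log units; within the scatter) falls within the scatter, with no direction claimed. Compound 4 is therefore expected to give about 25 nM in this assay, in a range from 8 nM to 80 nM.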

Compound 4, half-maximal inhibitory concentration: 6 nM
Beside the measured number, compound 4's estimate is 4.2-fold (0.62 log units) above it, and the stated range ends above it.
By their numbers in this assay, from the lowest: compound 4; then compound 3; then compounds 1 and 2 (each within the scatter of the next).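

Replacing methoxycarbonyl with methylsulfonyl on the aromatic carbon gives a 2.8-fold lower number from compound 3 to compound 4 (0.45 log units; beyond the scatter) in this assay and so, although modest, lies beyond the scatter; the substituent on this ring therefore matters in its own right, even though the two groups are counted with the same hydrogen-bond donors and acceptors. The large advantage over the oxygen-bound chains also holds for a second aryl group, with a 580-fold lower number from compound 2 to compound 4 (2.76 log units; beyond the scatter) and a 370-fold lower number from compound 1 to compound 4 (2.57 log units; beyond the scatter) as the steps, so it is not confined to 4-(methoxycarbonyl)phenyl. Nothing available here explains the difference between the two substituents.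

The compounds shown leave open how a nitrile, a trifluoromethyl, a carboxylic acid or an amine would behave at this place on the ring. They also leave open whether methylsulfonyl would keep this standing on a ring carrying further substituents.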